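From 2,5-Dimethylphenyl to 4-Ethylphenyl on a Shared Core

The compounds below may be only part of what the source reports. "The series", "measured", "known", "first", "only" and "open" are said of these compounds alone.

In a functional assay on U-87MG ATCC cells for inhibition, with U-87 MG (Homo sapiens) as the target, read by MTT assay, with a stated time of 72 h (a higher number here means a weaker inhibitor, a lower number a stronger inhibitor), compound 1 `Cc1ccc(C)c(C(Nc2ccccn2)c2ccc3cccnc3c2O)c1` gives 13800 nM, the higher of the two exact numbers available. Compound 3 `Oc1ccc2scnc2c1C(c1ccc(F)cc1)N1CCCCC1` gives 1000 nM, and the gap between these two values lies beyond the usual scatter of repeated measurements. In this assay, compound 2 `COc1ccc(C(Nc2cc(C)ccn2)c2ccc3cccnc3c2O)cc1O` returns only a limit, > 10000 nM, and not an exact number.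

Compound 4 `CCc1ccc(C(Nc2ccccn2)c2ccc3cccnc3c2O)cc1` has not yet been measured. It has the same atoms as compound 1, joined differently: 4-ethylphenyl in place of 2,5-dimethylphenyl on a saturated chain carbon bound to an aromatic carbon and a nitrogen on an aromatic ring. In words, it carries 4-ethylphenyl in place of 2,5-dimethylphenyl on a saturated chain carbon bound to an aromatic carbon and a nitrogen on an aromatic ring.

Among the compounds with values here, no measured pair shows what a change of this kind does, so no shift beyond the scatter is expected in this assay, in either direction. The best guide is compound 1, at 13800 nM. The expected change is a 1.2-fold lower number from compound 1 to compound 4 (0.06 log units; within the scatter), which stays within the scatter. For compound 4, the estimated value is 12000 nM, with an expected range of 5000 nM to 30000 nM.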

Compound 4, half-maximal inhibitory concentration: 9300 nM
Estimate against measurement, compound 4: 1.3-fold (0.11 log units) above; measured number inside the range.
By their numbers in this assay, from the lowest: compound 3; then compounds 4 and 1 (each within the scatter of the next).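

Rearranging the same carbon atoms, from 2,5-dimethylphenyl to 4-ethylphenyl, gives a 1.5-fold lower number from compound 1 to compound 4 (0.17 log units; within the scatter), the first reading of any change at this position. On the shared core, then, this assay does not tell these two groups apart, so for this pair the way the carbons are arranged on the aromatic ring makes no visible difference. Both numbers also lie close to the one value reported only as a limit: the limit of > 10000 nM in this assay, at which 1 of the 4 values shown sits.

As far as these compounds go, whether a different kind of group at this position, such as an amine, a carboxylic acid or a phenyl ring carrying a longer chain, would move the number beyond the scatter stays open. Also open, from the compounds shown here alone, is whether the same exchange would behave alike on another core, such as that of compound 3.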